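Fluorine on the central ring in two related series

This account rests on a few compounds, and the source may have more. Where it says the series, first, only, none or still open, it means among the compounds named here.

Measured compounds:
- Compound 1, `N#Cc1cccc(COc2ccc(-c3cc(CN4CCN(Cc5ccc(C(F)(F)F)cc5)CC4)no3)cc2)c1`: 800 nM
- Compound 2, `N#Cc1cccc(COc2ccc(-c3cc(CNC4CCN(Cc5ccccc5)CC4)no3)cc2)c1`: 2500 nM
- Compound 3, `N#Cc1cccc(COc2ccc(-c3cc(CN4CCN(Cc5ccc(C(F)(F)F)cc5)CC4)no3)c(F)c2)c1`: 1200 nM

Of the compounds shown here, three have been tested in a functional assay on MCF7 cells (Homo sapiens) for antiproliferative activity, read by sulforhodamine B assay, with a stated time of 72 h; a higher number here means a weaker inhibitor, a lower number a stronger inhibitor. Compound 1, `N#Cc1cccc(COc2ccc(-c3cc(CN4CCN(Cc5ccc(C(F)(F)F)cc5)CC4)no3)cc2)c1`, gives 800 nM in this assay, and compound 2, `N#Cc1cccc(COc2ccc(-c3cc(CNC4CCN(Cc5ccccc5)CC4)no3)cc2)c1`, gives 2500 nM. The difference between these two cores is not broken down here; compound 2 gives the highest number of the three, and its gap to compound 1 lies beyond the scatter.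

Compound 3, `N#Cc1cccc(COc2ccc(-c3cc(CN4CCN(Cc5ccc(C(F)(F)F)cc5)CC4)no3)c(F)c2)c1`, carries one change relative to compound 1: fluoro in place of hydrogen on an aromatic carbon. This gave a 1.5-fold higher number from compound 1 to compound 3 (0.18 log units; within the scatter).

Compound 4, `N#Cc1cccc(COc2ccc(-c3cc(CNC4CCN(Cc5ccccc5)CC4)no3)cc2F)c1`, is not yet measured. It differs from compound 2 by fluoro in place of hydrogen on an aromatic carbon. This is the same kind of change as that from compound 1 to compound 3, but not the same: in compound 3 the fluoro sits ortho to a large group and meta to a (3-cyanobenzyl)oxy group, while in compound 4 it sits ortho to a (3-cyanobenzyl)oxy group and meta to a large group.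

In this assay the step expected from compound 2 to compound 4 is a 1.2-fold higher number from compound 2 to compound 4 (0.08 log units; within the scatter), comparable to the earlier one, because a 1.5-fold higher number from compound 1 to compound 3 (0.18 log units; within the scatter) stayed within the scatter. Compound 4 is therefore estimated at 3000 nM, with a likely range from 1500 nM to 7000 nM, wider than the earlier step since the place of the fluoro differs.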

Compound 4, half-maximal inhibitory concentration: 2700 nM
Compound 4: middle estimate off by 1.1-fold (0.05 log units), on the high side; measured number inside the range.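

In this assay, fluoro in place of hydrogen on an aromatic carbon, ortho to a (3-cyanobenzyl)oxy group and meta to a large group, gave a 1.1-fold higher number from compound 2 to compound 4 (0.03 log units; within the scatter), so on this core the change left the number within the scatter. Set beside the earlier step, the change behaves alike on the two cores, with neither step moving the number beyond the scatter and the two steps not differing from each other: the same change on two cores in this assay, a 1.5-fold higher number (0.18 log units; within the scatter) from compound 1 to compound 3 and a 1.1-fold higher number (0.03 log units; within the scatter) from compound 2 to compound 4, 1.4-fold (0.14 log units) apart, within the scatter of two such steps This shows only that a single fluoro was tolerated on both cores, in one cell assay and across two pairs; it does not show a strict transfer from one core to the other, since the fluoro occupies a different place in each pair, ortho to a large group in compound 3 and ortho to a (3-cyanobenzyl)oxy group in compound 4.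

The compounds shown leave open whether each core would respond in the same way with the fluoro in the place it holds on the other core. They also leave open whether a chlorine atom, a methyl group or a methoxy group on the same aromatic carbon would shift the number beyond the scatter on either core.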